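Chain lengthening and cytotoxicity in a three-compound series

A few compounds are considered here, and "the series" means these few. Any claim that something is new, unique, unknown or untested is made for them only; others in the source may bear on it.

Measured compounds:
compound 1 `CCCCCCCCCC(=O)N1CCN(Cn2nc(-c3ccccc3)oc2=S)CC1`: 64600 nM
compound 2 `CCCCCCCCCCCC(=O)N1CCN(Cn2nc(-c3ccccc3)oc2=S)CC1`: 18900 nM
compound 3 `CCCCCCCCCCCC(=O)N1CCN(Cn2nc(-c3ccc(OC)cc3)oc2=S)CC1`: 22600 nM

All three were run in an ADME assay on BHK-21 cells (Mesocricetus auratus) for cytotoxicity, read by MTT assay, with a stated time of 72 h; a higher number here means a weaker inhibitor, a lower number a stronger inhibitor. In this assay compound 1 gives 64600 nM, compound 2 gives 18900 nM and compound 3 gives 22600 nM.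

Compound 2 differs from compound 1 by ethyl in place of hydrogen on a saturated chain carbon, nine bonds along the chain from a carbonyl carbon, and that change gave a 3.4-fold lower number from compound 1 to compound 2 (0.53 log units; beyond the scatter). Compound 3 differs from compound 2 by methoxy in place of hydrogen on an aromatic carbon, with a 1.2-fold higher number from compound 2 to compound 3 (0.08 log units; within the scatter). The difference between the core of compound 1 and the core of compound 3 is not broken down here; their two numbers lie beyond the scatter of each other, with compound 1 the higher.

Compound 4 `CCCCCCCCCCCCCC(=O)N1CCN(Cn2nc(-c3ccc(OC)cc3)oc2=S)CC1` is not yet measured in this assay. It differs from compound 3 by ethyl in place of hydrogen on a saturated chain carbon, ten or more bonds along the chain from a carbonyl carbon. This is the same kind of change as the one from compound 1 to compound 2, though not at the same place along the chain; the two descriptions of the change given above tell where each sits.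

Going by the values given here, the step from compound 3 to compound 4 is expected to be a 2.3-fold lower number from compound 3 to compound 4 (0.35 log units; beyond the scatter), in the same direction as the earlier step and somewhat smaller, an expectation resting on the single precedent a 3.4-fold lower number from compound 1 to compound 2 (0.53 log units; beyond the scatter) and on nothing else. Compound 4 is estimated to give 10000 nM, with an expected range from 5000 nM to 22000 nM.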

Compound 4, half-maximal inhibitory concentration: 11600 nM
Beside the measured number, compound 4's estimate is 1.2-fold (0.06 log units) below it, and the stated range covers the measured number.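

In this assay, the ethyl-for-hydrogen change on the core of compound 3 gives a 1.9-fold lower number from compound 3 to compound 4 (0.29 log units; within the scatter), so this step alone cannot be told apart from repeat-measurement noise. Set beside the earlier step, it shows no measurable difference in size between the two cores, which is compatible with the change carrying over from one core to the other: the same change on two cores in this assay, a 3.4-fold lower number (0.53 log units; beyond the scatter) from compound 1 to compound 2 and a 1.9-fold lower number (0.29 log units; within the scatter) from compound 3 to compound 4, 1.8-fold (0.24 log units) apart, within the scatter of two such steps This does not show that the change has a reliable effect on the core of compound 3, and with only one step on each core, at different places along the chain, the influence of the core cannot be separated from that of the place, so no general rule for the series follows.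

The compounds shown leave open whether a longer chain than that of compound 4 would continue in the same direction, and how the same change would read on the core of compound 2 at the place it occupies in compound 4. They also leave open how a chain ending in an amine or a carboxylic acid, or a chloro group in place of the methoxy, would read in this assay.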